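This account rests on a few compounds, and the source may have more. Where it says the series, first, only, none or still open, it means among the compounds named here.

In a functional assay on A549 cells (Homo sapiens) for antiproliferative activity, read by CCK-8 assay, with a stated time of 72 h (on this read-out lower numbers stand for stronger inhibition and higher numbers for weaker inhibition), compound 1 `CCc1ccc(SCc2ccc(/C=C/C(=O)Nc3ccccc3N)cc2)cc1` gives 1300 nM. Among the measured compounds shown here, this is the only number available, so compound 1 cannot yet be ranked as strong or weak against a relative. Compound 2 `COC(=O)c1ccccc1SCc1ccc(C(=O)Nc2ccccc2N)cc1` offers no comparison, since its entry reads "not determined" (no result reported). Compound 3 `CC(C)(C)c1ccc(SCc2ccc(/C=C/C(=O)Nc3ccccc3N)cc2)cc1` keeps the core of compound 1 and alters one group, with tert-butyl in place of ethyl on an aromatic carbon. The same difference can be read as 4-ethylphenyl to 4-(tert-butyl)phenyl. For the measured compounds named here, no pair of measured compounds shows what a swap of this kind does, so any forecast here is loose. The expected step of a 1.2-fold higher number from compound 1 to compound 3 (0.09 log units; within the scatter) is small, leaning slightly toward weaker inhibition and probably not beyond the usual scatter of this assay. The estimate for compound 3 is 1600 nM, with an expected range of 600 nM to 4200 nM.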

Compound 3, half-maximal inhibitory concentration: 640 nM
Estimate against measurement, compound 3: 2.5-fold (0.40 log units) above, and the stated range covers the measured number.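

Before this result, this assay held only one number for this series, so nothing showed how activity responds to a change in the group on the aromatic carbon, para to a large group. Replacing ethyl with tert-butyl there gives a 2.0-fold lower number from compound 1 to compound 3 (0.31 log units; beyond the scatter) and this modest step shows that the position accepts the larger group, with 4 heavy atoms in place of 2, while inhibition becomes stronger rather than weaker. Nothing available explains why the step runs in this direction.

Going by these compounds, with a single step, it remains open whether a still larger carbon group, such as a longer chain like n-hexyl, would strengthen inhibition further or reverse the gain. On these data alone, it is also open how an amine or a carboxylic acid at the same position would behave.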